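The source may report more compounds than this note shows. Statements on the series, on what has been measured and on what is new or still open speak of the compounds shown alone.

Measured so far:
compound 1 `COc1ccc(S(=O)(=O)n2c(-c3cn(-c4ccccc4)nc3-c3ccc(F)cc3)nc3ccccc32)cc1`: 105000 nM
compound 2 `Cc1ccc(C)c(S(=O)(=O)n2c(-c3cn(-c4ccccc4)nc3-c3ccc(F)cc3)nc3ccccc32)c1`: 122000 nM

Both values come from an ADME assay on cells (Hepatocyte, Mus musculus) for cytotoxicity, read by MTT assay, with a stated time of 24 h; on this read-out lower numbers stand for higher toxicity in this test and higher numbers for lower toxicity in this test. They lie within the scatter of each other, so compound 2 stands level with compound 1 on the two numbers available. The measured step is a 1.2-fold higher number from compound 1 to compound 2 (0.07 log units; within the scatter).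

Compound 3 `O=S(=O)(c1ccc(F)cc1)n1c(-c2cn(-c3ccccc3)nc2-c2ccc(F)cc2)nc2ccccc21` is still to be measured. Its change from compound 2 is 4-fluorophenyl in place of 2,5-dimethylphenyl on a sulfonyl sulfur, with 4-fluorophenyl in place of 2,5-dimethylphenyl on a sulfonyl sulfur. Going by the values given here, only one measured step bears on this, a swap of the group at the same sulfonyl sulfur, and it was small. No step beyond the scatter is therefore expected in this assay, and no direction can be claimed with any weight. The expected step is a 1.1-fold lower number from compound 2 to compound 3 (0.04 log units; within the scatter). For compound 3 the estimated value is 110000 nM, with an expected range of 65000 nM to 190000 nM.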

Compound 3, half-maximal cytotoxic concentration: 174000 nM
Compound 3: middle estimate off by 1.6-fold (0.20 log units), on the low side; measured number inside the range.
By their numbers in this assay, from the lowest: compounds 1, 2 and 3 (each within the scatter of the next).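

At the sulfonyl sulfur, 4-fluorophenyl in place of 2,5-dimethylphenyl gives a 1.4-fold higher number from compound 2 to compound 3 (0.15 log units; within the scatter) in this assay, and fluoro in place of methoxy on an aromatic carbon gives a 1.7-fold higher number from compound 1 to compound 3 (0.22 log units; within the scatter). The fluoro-bearing ring is thus a third aryl group at this position that the read-out does not separate from the other two, and the methoxy, dimethyl and fluoro patterns stand level on these numbers. No supporting data bear on these steps.

Open, as far as these compounds go, is whether a non-aromatic group on the sulfonyl sulfur, such as a longer alkyl chain, or an aryl group carrying an amine or a carboxylic acid, would give a step beyond the scatter. Changes away from the sulfonyl sulfur also remain open, as all three compounds share the rest of the structure.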